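The compounds below may be only part of what the source reports. "The series", "measured", "known", "first", "only" and "open" are said of these compounds alone.

Measured so far in a functional assay on MGC-803 cells (Homo sapiens) for antiproliferative activity, read by MTT assay, with a stated time of 72 h; on this read-out lower numbers stand for stronger inhibition and higher numbers for weaker inhibition:

- compound 1 `Cc1ccccc1-n1nc(-c2ccccc2)nc1CNc1ccc(C(=O)NO)cc1` gives 12300 nM
- compound 2 `O=C(NO)c1ccc(NCc2nc(-c3ccccc3)nn2-c2ccc(Br)cc2)cc1` gives 9300 nM
- compound 3 `O=C(NO)c1ccc(NCc2nc(-c3ccccc3)nn2-c2ccccc2)cc1` gives 17700 nM

Compound 3, at 17700 nM, lies within the usual scatter of both other compounds, so the three cannot be put in any order. Compound 4 `Cc1cccc(-n2nc(-c3ccccc3)nc2CNc2ccc(C(=O)NO)cc2)c1` has methyl in place of hydrogen on an aromatic carbon of compound 3, so phenyl becomes 3-methylphenyl (methyl in place of hydrogen on an aromatic carbon).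

The closest guide is a 1.4-fold higher number from compound 1 to compound 3 (0.16 log units; within the scatter), where a methyl is removed from a 2-methylphenyl group. Read backwards, this is the same kind of change, though the methyl's place on the ring differs. Replacing bromo with hydrogen gives a 1.9-fold higher number from compound 2 to compound 3 (0.28 log units; within the scatter), and exchanging 2-methylphenyl for 4-bromophenyl gives a 1.3-fold lower number from compound 1 to compound 2 (0.12 log units; within the scatter). All three steps stay within the scatter, so this small series offers no sign that such changes on this ring move the number much. For the measured compounds named here, with only three compounds, that is thin evidence.

No step beyond the scatter is therefore expected, and the direction is not firmly predicted. The estimated change is a 1.4-fold lower number from compound 3 to compound 4 (0.13 log units; within the scatter) and it would be too small to read as a real difference. For compound 4 the estimate is 13000 nM, with an expected range from 7000 nM to 24000 nM as its limits.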

Compound 4, half-maximal inhibitory concentration: 13200 nM
Compound 4: the middle estimate sits 1.0-fold (0.01 log units) below what was measured, and the stated range covers the measured number.
By their numbers in this assay, from the lowest: compounds 2, 1, 4 and 3 (each within the scatter of the next).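

In this assay, methyl in place of hydrogen on an aromatic carbon, meta to a large group, gives a 1.3-fold lower number from compound 3 to compound 4 (0.13 log units; within the scatter) and so shows that a methyl at this place, like the 2-methylphenyl and 4-bromophenyl groups before it, brings no step beyond the scatter. The comparisons among the substituted rings agree, with a 1.4-fold higher number from compound 2 to compound 4 (0.15 log units; within the scatter) for 3-methylphenyl in place of 4-bromophenyl and a 1.1-fold higher number from compound 1 to compound 4 (0.03 log units; within the scatter) for 3-methylphenyl in place of 2-methylphenyl, so all four groups on this aromatic nitrogen remain impossible to rank and the methyl's place on the ring shows no measurable influence in this small set. No accompanying measurement is available to explain this flat picture.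

Still open, as far as these compounds go, is whether a group of another kind on this ring, such as an amine, a carboxylic acid or a longer chain, would give a step beyond the scatter. The compounds shown also leave open whether changes elsewhere on the shared core, such as on its other phenyl group, would move the number more than these have.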